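A few compounds are considered here, and "the series" means these few. Any claim that something is new, unique, unknown or untested is made for them only; others in the source may bear on it.

Compound 1 has the structure `CCN(CC)c1cc2[nH]c(C3CCCCC3)nc2cc1NC(=O)NCc1ccccc1`. In an ADME assay on Vero cells (Chlorocebus sabaeus) for cytotoxicity, read by resazurin assay, with a stated time of 3 days (on this read-out lower numbers stand for stronger inhibition and higher numbers for weaker inhibition), compound 1 gives > 100 ug/mL, which is a limit of the assay and not a number. Two neighbours share its core. Compound 2, with structure `CN(C)c1cc2[nH]c(C3CCCCC3)nc2cc1NC(=O)OCc1ccccc1`, gives > 100 ug/mL in this assay, again a limit rather than a number. Compound 3, with structure `CCCN(CCC)c1cc2[nH]c(C3CCCCC3)nc2cc1NC(=O)OCc1ccccc1`, gives > 100 ug/mL in this assay, also a limit. Among the measured compounds shown here, the one step measured between them, a step that the two limits leave unreadable from compound 2 to compound 3, cannot be read because both ends sit at a limit, and the same holds for every value shown: the limit of > 100 ug/mL in this assay, at which 3 of the 3 values shown sit.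

Compound 4 has the structure `CCN(CC)c1cc2[nH]c(C3CCCCC3)nc2cc1NC(=O)c1ccc(C)cc1`. The change from compound 1 is 4-methylphenyl in place of benzylamino on a carbonyl carbon. For the measured compounds named here, no measured step touches this part of the molecule; the only step on record concerns a different site and is itself unreadable. With nothing to point in either direction, compound 4 is expected to behave as compound 1 does in this assay, and the step expected is a number no higher from compound 1 to compound 4 (the limit leaves the size open), nothing beyond the scatter. Compound 4 is therefore estimated at 100 ug/mL in this assay, within a range of 50 ug/mL to 200 ug/mL, most likely reported again only as a limit.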

Compound 4, half-maximal inhibitory concentration: > 100 ug/mL
Compound 4: no number, only a limit; the forecaster's own chance of this, stated with the estimate: 80%; the middle value sits exactly at the limit.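

No step can be read between compound 1 and compound 4 in this assay, because both end at a limit and not a number: the limit of > 100 ug/mL in this assay, at which 4 of the 4 values shown sit.

The compounds shown leave open what number any of them would reach in this assay, and so whether 4-methylphenyl and benzylamino on the carbonyl carbon differ there at all.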